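Swapping the Imidazole Sulfonamide for a Bromophenyl Analogue

This account rests on a few compounds, and the source may have more. Where it says the series, first, only, none or still open, it means among the compounds named here.

Compound 1 `CC1CCN(C2CCN(S(=O)(=O)c3cn(C)cn3)CC2)CC1` was tested in an ADME assay on HCT-116 cells (Homo sapiens) for cytotoxicity, read by CellTiter-Glo, with a stated time of 72 h; on this read-out lower numbers stand for stronger inhibition and higher numbers for weaker inhibition. In this assay compound 1 gives only a limit, > 10000 nM, so no number is known for it. A second compound, compound 2 `Cc1cc(C)c(S(=O)(=O)NC2CCC(N3CCC(C)CC3)CC2)c(C)c1`, was also run in this assay, and compound 2 likewise returns only a limit, > 5000 nM. Compound 1 therefore stands at a limit, and the other value shown is a limit as well, so no ordering of the two can be drawn.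

Compound 3 `CC1CCN(C2CCN(S(=O)(=O)c3ccccc3Br)CC2)CC1` has not yet been measured. It differs from compound 1 in one place: 2-bromophenyl in place of 1-methyl-1H-imidazol-4-yl on a sulfonyl sulfur. Going by the values given here, no pair of measured compounds differing in a single place is known here, so the size of this step cannot be read from the data. From the compounds shown here alone, because compound 1 sits at a limit, any change in this assay remains open. Compound 3 is expected to stay weak, with a step from compound 1 estimated at a step that the limit leaves unreadable from compound 1 to compound 3, likely none beyond the scatter. Compound 3 is expected to give about 15000 nM, in a range from 3000 nM to 60000 nM, and a limit rather than a number is again thought likely.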

Compound 3, half-maximal inhibitory concentration: > 5000 nM
Compound 3 was reported as a limit; the forecaster's own chance of this, stated with the estimate: 75%; the middle value does not contradict the limit.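

In this assay, going by these compounds alone, compound 3 gives > 5000 nM, a limit and not a number, and compound 1 also stands at a limit, so no step between them can be read. From the compounds shown here alone, whether 2-bromophenyl and 1-methyl-1H-imidazol-4-yl on a sulfonyl sulfur differ at all remains open.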